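Lengthening the acid chain of compound 2

A few compounds are considered here, and "the series" means these few. Any claim that something is new, unique, unknown or untested is made for them only; others in the source may bear on it.

Compound 1 `O=C(O)CN1C(=O)/C(=C/c2nc3ccccc3n2Cc2ccc(F)cc2)SC1=S`: 13900 nM
Compound 2 `O=C(O)CN1C(=O)/C(=C/c2nc3ccccc3n2Cc2ccccc2F)SC1=S`: 640 nM
Compound 3 `O=C(O)CN1C(=O)/C(=C/c2nc3ccc(F)cc3n2Cc2ccccc2F)SC1=S`: > 50000 nM (a limit, not a number)

Compound 2 at 640 nM holds the lower of the two actual numbers in a functional assay on HeLa cells (Homo sapiens) for cytotoxicity, read by MTT assay, with a stated time of 48 h (on this read-out lower numbers stand for stronger inhibition and higher numbers for weaker inhibition), and is the point of comparison here. Compound 4 `O=C(O)CCN1C(=O)/C(=C/c2nc3ccccc3n2Cc2ccccc2F)SC1=S` has carboxymethyl in place of carboxy on a saturated chain carbon bound to an amide-type nitrogen in a ring, which also reads as carboxymethyl to 2-carboxyethyl. Among the measured compounds shown here, no measured step changed this place. The steps of a 22-fold lower number from compound 1 to compound 2 (1.34 log units; beyond the scatter) and an at least 78-fold higher number from compound 2 to compound 3 (1.89 log units; beyond the scatter) were both large, so a single change in this small set can move the number far. Compound 2 already sits lowest (640 nM), so a rise is expected, of uncertain size. The expected step in this assay is a 3.9-fold higher number from compound 2 to compound 4 (0.59 log units; beyond the scatter) and points to a higher number. Compound 4 is estimated at 2500 nM (expected range 400 nM to 20000 nM).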

Compound 4, half-maximal inhibitory concentration: 26500 nM
Estimate against measurement, compound 4: 11-fold (1.03 log units) below; the whole stated range lies below it.
By their numbers in this assay, from the lowest: compound 2; then compounds 1 and 4 (each within the scatter of the next). At a limit, above all of these: compound 3.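

In this assay, the change from carboxymethyl to 2-carboxyethyl gives a 41-fold higher number from compound 2 to compound 4 (1.62 log units; beyond the scatter), so the acid chain is a place where a small change moves the number far. Both compounds carry the acid group, so having that group is not enough to keep the number low: the length of its chain matters too. No measurement shown accounts for this step.

Going by these compounds, whether a longer chain, such as 3-carboxypropyl, would raise the number further remains open. So does the effect of an ester or a primary amide in place of the carboxylic acid on the shorter chain.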